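The source may report more compounds than this note shows. Statements on the series, on what has been measured and on what is new or still open speak of the compounds shown alone.

Measured compounds:
- compound 1 `Cc1cc(O)c(C(=O)/C=C/c2ccc(OCc3ccccc3)cc2)c(-c2ccccc2)c1C(=O)/C=C/c1ccc(OCc2ccccc2)cc1`: 30000 nM
- compound 2 `Cc1cc(O)c(C(=O)/C=C/c2ccc3ccccc3c2)c(-c2ccccc2)c1C(=O)/C=C/c1ccc2ccccc2c1`: "not active" (no number reported)
- compound 3 `Cc1cc(O)c(C(=O)/C=C/c2ccc(F)cc2)c(-c2ccc(Br)cc2)c1C(=O)/C=C/c1ccc(F)cc1`: 20000 nM

In an ADME assay on HEK293 cells (Homo sapiens) for cytotoxicity, read by MTT assay, with a stated time of 24 h (on this read-out higher numbers stand for weaker inhibition and lower numbers for stronger inhibition), compound 1 gives 30000 nM. Compound 3 gives 20000 nM in this assay, and the gap between compound 1 and compound 3 lies within the usual scatter, so the two cannot be told apart. Compound 2 is reported in this assay as "not active" (no number reported), without a number.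

Compound 4 `Cc1cc(O)c(C(=O)/C=C/c2ccc(OCc3ccccc3)cc2)c(-c2ccc(Br)cc2)c1C(=O)/C=C/c1ccc(OCc2ccccc2)cc1` differs from compound 1 by bromo in place of hydrogen on an aromatic carbon. Among the measured compounds shown here, the only comparison at hand, compound 1 against compound 3, changes two places at once and stays within the scatter, so no step beyond the scatter is expected from compound 1 to compound 4 in this assay.

Compound 4 is estimated at 25000 nM (range 10000 nM to 60000 nM), an expected step of a 1.2-fold lower number from compound 1 to compound 4 (0.08 log units; within the scatter).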

Compound 4, half-maximal inhibitory concentration: 25000 nM
For compound 4 middle estimate and measured number coincide at the digits printed, within the range that was stated.
By their numbers in this assay, from the lowest: compounds 3, 4 and 1 (each within the scatter of the next).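

In this assay, bromo in place of hydrogen on an aromatic carbon gives a 1.2-fold lower number from compound 1 to compound 4 (0.08 log units; within the scatter) and so leaves the read-out unchanged within the usual scatter. Among the compounds shown here, this is the first reading of phenyl to 4-bromophenyl as a single change, which the earlier comparison, changing two places at once, could not give. No supporting measurement bears on this result.

Still open, as far as these compounds go, is whether an amine or a carboxylic acid at this position would shift the read-out beyond the scatter. From the compounds shown here alone, whether bromo behaves alike on compound 2 also remains open.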